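Working notes: from compound 3 to compound 4

The source may report more compounds than this note shows. Statements on the series, on what has been measured and on what is new or still open speak of the compounds shown alone.

Measured in a functional assay on MCF7 cells (Homo sapiens) for cytotoxicity, read by MTT assay, with a stated time of 72 h; a higher number here means a weaker inhibitor, a lower number a stronger inhibitor:
- compound 1 `COc1cccc(/C=C2\CCC/C(=C\c3ccccc3Br)C2=O)c1OC`: 9700 nM
- compound 2 `COc1cccc(/C=C2\CCC/C(=C\c3cccc(Br)c3)C2=O)c1OC`: 11700 nM
- compound 3 `COc1cccc(/C=C2\CCC/C(=C\c3cccc(OC)c3OC)C2=O)c1`: 5900 nM

Compound 3 cannot be separated from the other two compounds on these numbers. The data show a 1.6-fold lower number from compound 1 to compound 3 (0.22 log units; within the scatter) and a 2.0-fold lower number from compound 2 to compound 3 (0.30 log units; within the scatter), so the three values form a single level with no order among them.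

The next compound is compound 4 `COc1cccc(/C=C2\CCC/C(=C\c3cc(Cl)cc(Cl)c3)C2=O)c1OC`, and the change is 3,5-dichlorophenyl in place of 3-methoxyphenyl on a double-bonded chain carbon bound to a double-bonded ring carbon. Going by the values given here, no measured compound carries the 3,5-dichlorophenyl group, so the data give no direct precedent for it. The nearest evidence is the pair with a bromo group on this same arm. Moving that group gave a 1.2-fold higher number from compound 1 to compound 2 (0.08 log units; within the scatter), and methoxy in place of bromo on an aromatic carbon gave the step from compound 2 to compound 3 already noted. Neither exchange left the scatter, so no step beyond the scatter is expected in this assay, and no direction is favoured with any confidence. The expected step is a 1.3-fold higher number from compound 3 to compound 4 (0.10 log units; within the scatter), which is an estimate only. The estimated value for compound 4 is 7500 nM, with an expected range from 2800 nM to 18000 nM, kept wide for the untested group.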

Compound 4, half-maximal inhibitory concentration: 4300 nM
The estimate for compound 4 lay 1.7-fold (0.24 log units) above the measured number, within the range that was stated.
By their numbers in this assay, from the lowest: compounds 4, 3, 1 and 2 (each within the scatter of the next, the first and the last beyond it).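

In this assay, going by these compounds alone, 3,5-dichlorophenyl is the first group on this double-bonded chain carbon to separate from another group, though only modestly: the data show a 2.7-fold lower number from compound 2 to compound 4 (0.43 log units; beyond the scatter) and a 2.3-fold lower number from compound 1 to compound 4 (0.35 log units; beyond the scatter), whereas no step among compound 1, compound 2 and compound 3 left the scatter. The exchange for 3-methoxyphenyl does not separate in the same way, as a 1.4-fold lower number from compound 3 to compound 4 (0.14 log units; within the scatter) stays within the scatter, so an arm with no hydrogen-bond acceptor sits at one level with an arm that carries one, and the bromo compounds and compound 3 remain a single level among themselves. Nothing available bears on why the 3,5-dichlorophenyl arm separates from the two bromophenyl arms.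

The compounds shown do not tell whether this modest separation belongs to chlorine in place of bromine or to the presence of two halogens on the ring, since a single-chlorine arm such as 3-chlorophenyl is not among them. Going by these compounds, how an arm carrying an amine or a carboxylic acid would read in this assay also stays open.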